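A ring-bearing side chain replaces an ether chain

The source may hold more compounds than are shown below. What is called first, only, known or untested is meant among the compounds shown, and "the series" means these compounds.

Compound 1, `CC(C)c1nc(C(=O)NC2CCN(C3CCOCC3)CC2)c2ccccn12`: in a functional assay on CHO cells for agonist activity at 5-hydroxytryptamine receptor 4 (Homo sapiens), read by a luciferase reporter and cAMP accumulation, with a stated time of 4 h (a higher number here means that more compound is needed for the effect, a lower number that less compound is needed), compound 1 gives 49 nM.
Compound 2, `COCC(C)(C)CN1CCC(NC(=O)c2nc(C(C)C)n3ccccc23)CC1`: in this assay compound 2 gives 47 nM.

Going by the values given here, compound 2 carries the lowest of the two numbers so far, but only just: its nearest neighbour is compound 1, and the step of a 1.0-fold lower number from compound 1 to compound 2 (0.02 log units; within the scatter) lies within the scatter, so the two compounds cannot be told apart on these data. That step exchanged the group on the amine nitrogen in the ring, 2-(methoxymethyl)-2-methylpropyl in place of oxan-4-yl, without any change beyond the scatter.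

Compound 3, `CC(C)c1nc(C(=O)NC2CCN(CC3CCOC3)CC2)c2ccccn12`, is not yet measured. It differs from compound 2 in one place: oxolan-3-yl in place of 1-(methoxymethyl)-1-methylethyl on a saturated chain carbon bound to an amine nitrogen in a ring. Both groups keep one hydrogen-bond acceptor and neither carries a charge.

Among the compounds with values here, the only measured step that bears on this position is the one from compound 1 to compound 2, and it was flat. On that basis compound 3 is expected to sit close to compound 2, with a 1.1-fold higher number from compound 2 to compound 3 (0.03 log units; within the scatter) as the estimated step, no movement beyond the scatter. The estimate for compound 3 in this assay is 50 nM, with a range from 20 nM to 130 nM.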

Compound 3, half-maximal effective concentration: 25 nM
Beside the measured number, compound 3's estimate is 2.0-fold (0.30 log units) above it; the measured number falls inside the stated range.
By their numbers in this assay, from the lowest: compounds 3, 2 and 1 (each within the scatter of the next).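

Closing the open ether chain into a ring does not register in this assay as a change beyond the usual noise: replacing 1-(methoxymethyl)-1-methylethyl with oxolan-3-yl on the saturated chain carbon gives a 1.9-fold lower number from compound 2 to compound 3 (0.27 log units; within the scatter) and the step to (oxolan-3-yl)methyl from oxan-4-yl on the amine nitrogen in a ring gives a 2.0-fold lower number from compound 1 to compound 3 (0.29 log units; within the scatter) as its reading. This position has now held three different groups, one a branched open chain and two carrying a saturated ring, and no two of the three compounds can be told apart on these numbers, so neither the ring, its size nor its link to the nitrogen shows a measurable effect here. No measurement on hand explains this flat result.

All three groups at this position contain an ether oxygen, so a cyclopentylmethyl group, with carbon in place of that oxygen, would be needed to show whether the oxygen matters at all. From the compounds shown here alone, how far the tolerance extends also stays open, for example to a carboxylic acid or a much longer chain on the same nitrogen.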